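Exchange on the aromatic nitrogen: compound 2 to compound 3

The source may report more compounds than this note shows. Statements on the series, on what has been measured and on what is new or still open speak of the compounds shown alone.

Measured so far in a functional assay on cells for antagonist activity at C-C chemokine receptor type 4 (Homo sapiens), read by GTPgammaS binding; on this read-out higher numbers stand for weaker inhibition and lower numbers for stronger inhibition:
- compound 1 `COc1nn(C(C)C)c2ncnc(NS(=O)(=O)c3cccc(Cl)c3Cl)c12`: 251 nM
- compound 2 `COc1nn(CC(N)=O)c2ncnc(NS(=O)(=O)c3cccc(Cl)c3Cl)c12`: 501 nM

Only these two compounds of the shared core carry numbers. Compound 2 and compound 1 sit within the scatter of each other: a 2.0-fold higher number from compound 1 to compound 2 (0.30 log units; within the scatter). Compound 3 `COc1nn(C2COC2)c2ncnc(NS(=O)(=O)c3cccc(Cl)c3Cl)c12` is not yet measured. Its change from compound 2 is oxetan-3-yl in place of carbamoylmethyl on an aromatic nitrogen.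

Going by the values given here, the one measured step that bears on this place is a 2.0-fold higher number from compound 1 to compound 2 (0.30 log units; within the scatter), and it did not move the number beyond the scatter. Among the compounds with values here, no measured compound carries an oxetan-3-yl group, so nothing is known about that group on its own. Because a 2.0-fold higher number from compound 1 to compound 2 (0.30 log units; within the scatter) stayed within the scatter, the step of a 1.6-fold lower number from compound 2 to compound 3 (0.19 log units; within the scatter) is expected to stay within the scatter as well, with no clear direction. Compound 3 is therefore estimated at 320 nM, with a range from 130 nM to 800 nM.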

Compound 3, half-maximal inhibitory concentration: 251 nM
Compound 3: middle estimate off by 1.3-fold (0.11 log units), on the high side; the measured number falls inside the stated range.
By their numbers in this assay, from the lowest: compounds 1, 3 and 2 (each within the scatter of the next).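

Going by these compounds alone, with oxetan-3-yl on the aromatic nitrogen, a four-membered non-aromatic ring enters this place for the first time, and in this assay its exchange for carbamoylmethyl gives a 2.0-fold lower number from compound 2 to compound 3 (0.30 log units; within the scatter). The entering group has 0 hydrogen-bond donors against 1 in the leaving group, yet the step stays within the scatter, as does the exchange for isopropyl, with no change at the digits printed from compound 1 to compound 3 (within the scatter). Isopropyl, carbamoylmethyl and oxetan-3-yl thus cannot be told apart at this place in this assay, and no measurement at hand explains this.

Still open, as far as these compounds go, is whether an amine, a carboxylic acid or a longer chain on this nitrogen would take the number beyond the scatter. From the compounds shown here alone, the methoxy group stays the same in all three compounds, so the effect of an ethoxy group or a chlorine atom in its place remains unknown.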